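Methoxy in place of bromo in a cytotoxicity series

The source may hold more compounds than are shown below. What is called first, only, known or untested is meant among the compounds shown, and "the series" means these compounds.

Of the compounds shown here, two of this family have so far been tested in a functional assay on MCF7 cells (Homo sapiens) for cytotoxicity, read by MTT assay, with a stated time of 48 h; on this read-out lower numbers stand for stronger inhibition and higher numbers for weaker inhibition. Compound 1, `COc1ccc(NC(=O)c2cn(-c3ccccc3)nc2-c2ccccc2)cc1`, gives 1710 nM. Compound 2, `COc1ccc(-c2nn(-c3ccccc3)cc2C(=O)Nc2ccc(Br)cc2)cc1`, gives 8210 nM, the higher of the two numbers; its gap to compound 1 is beyond the usual scatter of repeated measurements. Compound 3, `COc1ccc(NC(=O)c2cn(-c3ccccc3)nc2-c2ccc(OC)cc2)cc1`, is still unmeasured. Going from compound 2 to compound 3 the change is methoxy in place of bromo on an aromatic carbon. Among the measured compounds shown here, no measured pair shows this same change, so its effect has no direct precedent here. Compound 3 is also a close relative of compound 1, differing from it by one methoxy group, and in this assay compound 1 gives 1710 nM. Compound 3 is therefore expected to fall between the two measured numbers, at about 3000 nM, within a likely range of 1000 nM to 12000 nM. The expected step of a 2.7-fold lower number from compound 2 to compound 3 (0.44 log units; beyond the scatter) is a moderate move toward stronger inhibition.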

Compound 3, half-maximal inhibitory concentration: 1770 nM
Beside the measured number, compound 3's estimate is 1.7-fold (0.23 log units) above it; the measured number falls inside the stated range.
By their numbers in this assay, from the lowest: compounds 1 and 3 (each within the scatter of the next); then compound 2.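

Turning (4-bromophenyl)amino into (4-methoxyphenyl)amino gives, in this assay, a 4.6-fold lower number from compound 2 to compound 3 (0.67 log units; beyond the scatter), the first measured sign that the choice of group at this place matters, and the move is toward stronger inhibition. Methoxy in place of hydrogen on the other aromatic ring gives a 1.0-fold higher number from compound 1 to compound 3 (0.01 log units; within the scatter), so in this single pair the added group produces no step that can be told apart from the scatter. Nothing available here explains either result.

It remains open whether the larger step comes from losing bromo or from gaining methoxy, as no compound shown has hydrogen at that carbon with the rest of compound 3 kept. An amine, a carboxylic acid or a longer chain such as ethoxy at that carbon would show how widely the number can move there.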